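From 4-methoxyphenyl to 3-amino-4-methoxyphenyl

The source may report more compounds than this note shows. Statements on the series, on what has been measured and on what is new or still open speak of the compounds shown alone.

In a functional assay on A549 cells (Homo sapiens) for inhibition, read by CCK-8 assay, with a stated time of 48 h (on this read-out higher numbers stand for weaker inhibition and lower numbers for stronger inhibition), compound 1 `COc1cc(-c2ccnc3cc(-c4ccc5c(ccn5C)c4)nn23)cc(OC)c1OC` gives 15 nM and compound 2 `COc1ccc(-c2cc3nccc(-c4cc(OC)c(OC)c(OC)c4)n3n2)cc1` gives 376 nM, the higher of the two numbers. Compound 3 `COc1ccc(-c2cc3nccc(-c4cc(OC)c(OC)c(OC)c4)n3n2)cc1N` carries amino in place of hydrogen on an aromatic carbon of the 4-methoxyphenyl group, ortho to a methoxy group: amino in place of hydrogen on an aromatic carbon. For the measured compounds named here, the only measured step changing this group is large, a 25-fold higher number from compound 1 to compound 2 (1.40 log units; beyond the scatter), and it shows that the number responds to changes here. A smaller move towards stronger inhibition is expected, an estimated step of a 4.7-fold lower number from compound 2 to compound 3 (0.67 log units; beyond the scatter). Compound 3 is expected at 80 nM, with an estimated range of 15 nM to 350 nM.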

Compound 3, half-maximal inhibitory concentration: 138 nM
Beside the measured number, compound 3's estimate is 1.7-fold (0.24 log units) below it, and the stated range covers the measured number.
By their numbers in this assay, from the lowest: compound 1; then compound 3; then compound 2.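

Amino in place of hydrogen, ortho to a methoxy group, gives a 2.7-fold lower number from compound 2 to compound 3 (0.44 log units; beyond the scatter) here, so this aromatic carbon can take a small substituent without loss and the number moves towards stronger inhibition. The step closes only part of the gap, since 3-amino-4-methoxyphenyl in place of 1-methyl-1H-indol-5-yl still leaves a 9.2-fold higher number from compound 1 to compound 3 (0.96 log units; beyond the scatter) on the same core. Nothing available accounts for the size of the amino step.

Still open, as far as these compounds go, is whether a hydroxyl, a dimethylamino or an acetamide group on this carbon would move the number further than amino does.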